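A few compounds are considered here, and "the series" means these few. Any claim that something is new, unique, unknown or untested is made for them only; others in the source may bear on it.

The three measured compounds share one core and differ only in the group on the amide carbonyl carbon. In an assay on LtK cells with ATP-sensitive inward rectifier potassium channel 11 (Homo sapiens) as the target (on this read-out higher numbers stand for an effect only at larger amounts of compound and lower numbers for an effect already at smaller amounts), compound 1 `C/C=C/C(=O)Nc1c(C(O)(C(F)(F)F)C(F)(F)F)ccc2ccccc12` gives 72 nM. Compound 2 `O=C(Nc1c(C(O)(C(F)(F)F)C(F)(F)F)ccc2ccccc12)C1CCC1` gives 45 nM in this assay, and the step of a 1.6-fold lower number from compound 1 to compound 2 (0.20 log units; within the scatter) stays within the scatter. Compound 3 `O=C(Nc1c(C(O)(C(F)(F)F)C(F)(F)F)ccc2ccccc12)c1cc(Cl)cc(Cl)c1` gives 306 nM in this assay, the highest number of the three; both a 4.3-fold higher number from compound 1 to compound 3 (0.63 log units; beyond the scatter) and a 6.8-fold higher number from compound 2 to compound 3 (0.83 log units; beyond the scatter) lie beyond the scatter, so the 3,5-dichlorophenyl group on the carbonyl carbon has given a higher number than either the prop-1-en-1-yl or the cyclobutyl group.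

Compound 4 `O=C(Nc1c(C(O)(C(F)(F)F)C(F)(F)F)ccc2ccccc12)c1cccs1` differs from compound 3 by thiophen-2-yl in place of 3,5-dichlorophenyl on a carbonyl carbon. Going by the values given here, no measured step exchanges one aromatic ring for another, so the only steps that bear on this change are a 4.3-fold higher number from compound 1 to compound 3 (0.63 log units; beyond the scatter) and a 6.8-fold higher number from compound 2 to compound 3 (0.83 log units; beyond the scatter), which show the dichlorophenyl group standing modestly apart from the two non-aromatic groups. Thiophen-2-yl is again an aromatic ring, but a five-membered one with one hetero atom rather than the six-membered ring of carbon only. The expected outcome is a step of a 2.0-fold lower number from compound 3 to compound 4 (0.31 log units; beyond the scatter), a modest lowering that leaves compound 4 between compound 3 and compound 1. Compound 4 is therefore estimated at 150 nM in this assay, with a range from 50 nM to 450 nM.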

Compound 4, half-maximal effective concentration: 12 nM
Beside the measured number, compound 4's estimate is 13-fold (1.10 log units) above it; measured number below the stated range.
By their numbers in this assay, from the lowest: compound 4; then compounds 2 and 1 (each within the scatter of the next); then compound 3.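

In this assay the exchange of 3,5-dichlorophenyl for thiophen-2-yl on the carbonyl carbon gives a 26-fold lower number from compound 3 to compound 4 (1.41 log units; beyond the scatter) and is the largest step seen at this position, so an aromatic ring here does not in itself go with the higher number. Compound 4 also stands apart from both non-aromatic compounds, with a 3.8-fold lower number from compound 2 to compound 4 (0.57 log units; beyond the scatter) and a 6.0-fold lower number from compound 1 to compound 4 (0.78 log units; beyond the scatter) as the steps, so the four values do not sort into aromatic and non-aromatic groups: the two aromatic groups sit at opposite ends, with cyclobutyl and prop-1-en-1-yl in the middle. No measurement is at hand that accounts for the size of this exchange.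

The exchange alters ring size, the hetero atom and the two chlorine atoms together, so the compounds shown cannot tell which of these goes with the lower number. From the compounds shown here alone, a plain phenyl group or a pyridine on the carbonyl carbon would help to separate these features, and it also remains open whether thiophen-2-yl keeps its standing when other parts of the shared core change.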